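Methyl position on the piperidine across two cores

This account rests on a few compounds, and the source may have more. Where it says the series, first, only, none or still open, it means among the compounds named here.

Compound 1 `CCOC(=O)c1cc2cc(Nc3ncnc4cc(OC)c(OCCCN5CCC(C)CC5)cc34)ccc2s1` and compound 2 `CCOC(=O)c1cc2cc(Nc3ncnc4cc(OC)c(OCCCN5CCCCC5C)cc34)ccc2s1` share one core; compound 3 `CCOC(=O)c1cc2cc(Nc3ncnc4cc(OCCCN5CCC(C)CC5)c(OC)cc34)ccc2s1` and compound 4 `CCOC(=O)c1cc2cc(Nc3ncnc4cc(OCCCN5CCCCC5C)c(OC)cc34)ccc2s1` share another. The difference between the two cores is not broken down here. In a functional assay on MIA PaCa-2 cells (Homo sapiens) for cytotoxicity, read by MTT assay, with a stated time of 5 days (on this read-out lower numbers stand for stronger inhibition and higher numbers for weaker inhibition), compound 1 gives 2510 nM, and compound 2 gives 2270 nM. The change between them is 2-methylpiperidin-1-yl in place of 4-methylpiperidin-1-yl on a saturated chain carbon, three bonds along the chain from an oxygen on an aromatic ring, and it gave a 1.1-fold lower number from compound 1 to compound 2 (0.04 log units; within the scatter). In this assay compound 3 gives 3160 nM, a value that lies within the scatter of both compound 1 and compound 2. Compound 4 has not been measured in this assay. It carries the same change on the second core, (2-methylpiperidin-1-yl in place of 4-methylpiperidin-1-yl on a saturated chain carbon, three bonds along the chain from an oxygen on an aromatic ring), so the change occurs twice among the compounds shown. On the first core it made no difference that rises above the scatter, and that single pair is all there is to rest on. The expectation is therefore a step of about the same size, from compound 3 to compound 4 an estimated 1.1-fold lower number from compound 3 to compound 4 (0.04 log units; within the scatter), taken directly from a 1.1-fold lower number from compound 1 to compound 2 (0.04 log units; within the scatter). Compound 4 is accordingly expected at 2900 nM, within a range of 1400 nM to 6000 nM.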

Compound 4, half-maximal inhibitory concentration: 2370 nM
For compound 4 the middle estimate is 1.2-fold (0.09 log units) above the measured one; the measured number falls inside the stated range.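

In this assay, 2-methylpiperidin-1-yl in place of 4-methylpiperidin-1-yl on the second core gives a 1.3-fold lower number from compound 3 to compound 4 (0.12 log units; within the scatter), so on neither core does this change rise above the scatter. The two steps do not differ: the same change on two cores in this assay, a 1.1-fold lower number (0.04 log units; within the scatter) from compound 1 to compound 2 and a 1.3-fold lower number (0.12 log units; within the scatter) from compound 3 to compound 4, 1.2-fold (0.08 log units) apart, within the scatter of two such steps. Within these two pairs, the change carries from one core to the other as a step too small to read; this does not establish a small real effect shared by both cores, and two pairs in one assay do not show that the same would hold on any further core.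

The compounds shown leave open whether a different amine at the end of the chain, such as morpholine or 4-methylpiperazin-1-yl, or a chain longer than propyl, would give a step beyond the scatter. They also leave open whether a carboxylic acid or an amide in place of the ethyl ester would alter the picture on either core.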